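A few compounds are considered here, and "the series" means these few. Any claim that something is new, unique, unknown or untested is made for them only; others in the source may bear on it.

In an assay on cell membranes for binding affinity to Equilibrative nucleoside transporter 1 (Homo sapiens) (on this read-out lower numbers stand for stronger inhibition and higher numbers for weaker inhibition), compound 3 `CCCNc1nc2c(SCc3ccccc3)ncnc2n1C1O[C@H](CO)[C@@H](O)[C@H]1O` gives 5.3 nM. Compound 2 `CCNc1nc2c(SCc3ccccc3)ncnc2n1C1O[C@H](CO)[C@@H](O)[C@H]1O` gives 9.5 nM, which sits within the usual scatter of compound 3, while compound 1 `CCCNc1nc2c(NC3CCCC3)ncnc2n1[C@@H]1O[C@H](CO)[C@@H](O)[C@H]1O` gives 97 nM, a number beyond the scatter above it. Compound 4 `CCC(C)CNc1nc2c(SCc3ccccc3)ncnc2n1C1O[C@H](CO)[C@@H](O)[C@H]1O` has not yet been measured. It differs from compound 3 by ethyl in place of hydrogen on a saturated chain carbon bound to two saturated chain carbons. For the measured compounds named here, the only step that bears on this change is a chain extension of the same kind: a 1.8-fold lower number from compound 2 to compound 3 (0.25 log units; within the scatter), a change too small to count. Lengthening the side chain on the amino group therefore seems to leave this assay nearly untouched, so no step beyond the scatter is expected from compound 3 to compound 4, a 1.2-fold lower number from compound 3 to compound 4 (0.07 log units; within the scatter). Compound 4 is expected to give about 4.5 nM, within a range from 2 nM to 12 nM.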

Compound 4, inhibition constant: 3.6 nM
Compound 4: middle estimate off by 1.3-fold (0.10 log units), on the high side, and the stated range covers the measured number.
By their numbers in this assay, from the lowest: compounds 4, 3 and 2 (each within the scatter of the next, the first and the last beyond it); then compound 1.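

In this assay, adding ethyl on a saturated chain carbon bound to two saturated chain carbons, the propyl to 2-methylbutyl change, keeps the result within the scatter, with a 1.5-fold lower number from compound 3 to compound 4 (0.17 log units; within the scatter), so this position accepts the larger chain. Set against the ethyl chain of compound 2, the same chain gives a modest gain beyond the scatter, with a 2.6-fold lower number from compound 2 to compound 4 (0.42 log units; beyond the scatter). Nothing shown here explains this result.

On these data alone, whether a longer chain such as hexyl would hold this level remains open. So does the outcome of placing a hydroxyl or an amine on this chain.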